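A few compounds are considered here, and "the series" means these few. Any claim that something is new, unique, unknown or untested is made for them only; others in the source may bear on it.

Compound 2 `CCOc1ncc(-c2nc(C(F)(F)F)sc2N2CCN(C(=O)Cn3ccc4cnccc43)[C@H](C)C2)cn1` gives the lowest number of the two measured here: in a functional assay on U2OS cells for antagonist activity at C-X-C chemokine receptor type 3 (Homo sapiens), read by beta-arrestin recruitment (a lower number here means a stronger inhibitor, a higher number a weaker inhibitor), compound 2 gives 23 nM. Compound 1 `CC[C@@H]1CN(c2scnc2-c2nc3ccccc3[nH]2)CCN1C(=O)Cn1cnc2cccnc21`, a compound of different build, gives 604 nM in this assay, a higher number by a margin beyond the scatter; the two differ in several places at once, so the pair alone tells nothing about any single change.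

Compound 3 `CCOc1ncc(-c2nc(C(F)(F)F)sc2N2CCN(C(=O)Cn3cnc(C(F)(F)F)n3)[C@H](C)C2)cn1` is not yet measured. It differs from compound 2 in one place: a group of 9 heavy atoms (3 carbon, 3 nitrogen, 3 fluorine; one five-membered aromatic ring with 3 hetero atoms) in place of a group of 9 heavy atoms (7 carbon, 2 nitrogen; one five-membered aromatic ring with 1 hetero atom, one six-membered aromatic ring with 1 hetero atom), on a saturated chain carbon bound to a carbonyl carbon. Going by the values given here, with no measured pair of this kind to rest on, compound 3 is expected to give a somewhat higher number, a step of a 2.6-fold higher number from compound 2 to compound 3 (0.42 log units; beyond the scatter) that may still fall within the scatter. Compound 3 is estimated at 60 nM, with a range from 15 nM to 250 nM.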

Compound 3, half-maximal inhibitory concentration: 118 nM
Beside the measured number, compound 3's estimate is 2.0-fold (0.29 log units) below it; the range from low to high includes it.
By their numbers in this assay, from the lowest: compound 2; then compound 3; then compound 1.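

Exchanging the two-ring group of compound 2 for 3-(trifluoromethyl)-1H-1,2,4-triazol-1-yl, on a saturated chain carbon bound to a carbonyl carbon, gives a 5.1-fold higher number from compound 2 to compound 3 (0.71 log units; beyond the scatter) in this assay. Going by these compounds alone, this is the first single-place comparison, and it shows that the number responds to the group at this position, even with the heavy-atom count unchanged. No measurement at hand accounts for the step.

The compounds shown leave open how much of the step belongs to the trifluoromethyl group and how much to the triazole ring. Going by these compounds, how a plain phenyl ring or an amine would fare at this position also remains open.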